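Moving from 3-chlorophenyl to 4-fluorophenyl

The source may hold more compounds than are shown below. What is called first, only, known or untested is meant among the compounds shown, and "the series" means these compounds.

Values in an ADME assay on Vero 76 cells (Chlorocebus sabaeus) for cytotoxicity, read by MTT assay, with a stated time of 96 h (on this read-out higher numbers stand for lower toxicity in this test and lower numbers for higher toxicity in this test), are as follows
Compound 1 (`NS(=O)(=O)c1ccc(N2N=C(c3ccc(Oc4ccccc4)cc3)CC2c2ccccc2)cc1`) gives 85000 nM
Compound 2 (`NS(=O)(=O)c1ccc(N2N=C(c3ccc(Oc4ccccc4)cc3)CC2c2cccc(F)c2)cc1`) gives 28000 nM
Compound 3 (`NS(=O)(=O)c1ccc(N2N=C(c3ccc(Oc4ccccc4)cc3)CC2c2cccc(Cl)c2)cc1`) gives 88000 nM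

Compound 3 sits at the high end of these numbers. That end is shared (a 1.0-fold higher number from compound 1 to compound 3 (0.02 log units; within the scatter)) and the third value lies apart (a 3.1-fold higher number from compound 2 to compound 3 (0.50 log units; beyond the scatter)). Compound 4 (`NS(=O)(=O)c1ccc(N2N=C(c3ccc(Oc4ccccc4)cc3)CC2c2ccc(F)cc2)cc1`) brings 4-fluorophenyl in place of 3-chlorophenyl on a saturated ring carbon in the form of 4-fluorophenyl in place of 3-chlorophenyl on a saturated ring carbon. The closest measured step is fluoro in place of hydrogen (a 3.0-fold lower number from compound 1 to compound 2 (0.48 log units; beyond the scatter)), alongside the chloro for fluoro step already shown. For the measured compounds named here, no measured compound carries 4-fluorophenyl, so only a partial move toward compound 2 (28000 nM) is expected in this assay. The expected change is a lower number (a 1.8-fold lower number from compound 3 to compound 4 (0.25 log units; within the scatter)) of modest size. For compound 4 the estimated value is 50000 nM with 20000 nM to 100000 nM as the expected range.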

Compound 4, half-maximal cytotoxic concentration: 25000 nM
The estimate for compound 4 lay 2.0-fold (0.30 log units) above the measured number, and the stated range covers the measured number.
By their numbers in this assay, from the lowest: compounds 4 and 2 (each within the scatter of the next); then compounds 1 and 3 (each within the scatter of the next).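

In this assay, 4-fluorophenyl on this saturated ring carbon gives a lower number than plain phenyl (a 3.4-fold lower number from compound 1 to compound 4 (0.53 log units; beyond the scatter)) and than 3-chlorophenyl (a 3.5-fold lower number from compound 3 to compound 4 (0.55 log units; beyond the scatter)). Moving the fluoro from 3-fluorophenyl to 4-fluorophenyl stays within the scatter (a 1.1-fold lower number from compound 2 to compound 4 (0.05 log units; within the scatter)), so the two fluorophenyl groups read alike here, whichever ring position carries the fluoro, while 3-chlorophenyl stays level with plain phenyl. From the compounds shown here alone, whether 4-chlorophenyl would read like the fluoro pair or like 3-chlorophenyl stays open, as does how a methoxy or an amine on this ring would read. Nothing available here accounts for the gap between fluoro and chloro.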